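Replacing an Acetylthiophene Arm with an Ethoxyphenyl Group

The source may report more compounds than this note shows. Statements on the series, on what has been measured and on what is new or still open speak of the compounds shown alone.

Compound 3 `CCOC(=O)CCCCCOc1cccc(CN(C(=O)c2ccc(-c3ccc(C(C)=O)s3)cc2)C(C)C)c1` has been tested in an ADME assay on Raji cells (Homo sapiens) for cytotoxicity, read by CellTiter-Glo and resazurin assay, with a stated time of 72 h; on this read-out lower numbers stand for an effect already at smaller amounts and higher numbers for an effect only at larger amounts of compound. In this assay compound 3 gives > 26000 nM, which is a limit and not a number. Compound 1 `CCOC(=O)CCCCCOc1cccc(CN(C(=O)c2ccc(-c3cccc(N(C)C)c3)cc2)C(C)C)c1` likewise reaches only a limit, giving > 26000 nM. Compound 2 `CCOC(=O)CCCCCOc1cccc(CN(C(=O)c2ccc(-c3cccc(OC(C)C)c3)cc2)C(C)C)c1` also gives a limit of > 26000 nM. Compound 3 therefore stands where every shown value stands, at the limit of > 26000 nM in this assay, at which 3 of the 3 values shown sit. The step that the two limits leave unreadable from compound 1 to compound 2, the step that the two limits leave unreadable from compound 1 to compound 3 and the step that the two limits leave unreadable from compound 2 to compound 3 are all left unreadable by the limits on both sides.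

Compound 4 `CCOC(=O)CCCCCOc1cccc(CN(C(=O)c2ccc(-c3cccc(OCC)c3)cc2)C(C)C)c1` is not yet measured. It differs from compound 3 by 3-ethoxyphenyl in place of 5-acetylthiophen-2-yl on an aromatic carbon. Going by the values given here, none of the measured steps can give a size for this change, since each of them joins two limits. What they do show is that three different arms on the shared core, a dimethylamino-bearing phenyl, an isopropoxy-bearing phenyl and an acetyl-bearing thiophene, all leave the read-out at the limit. The ethoxyphenyl arm of compound 4 is close in kind to the isopropoxyphenyl arm of compound 2. Compound 4 is therefore expected to remain at the limit, with an estimated value of 40000 nM in a range from 15000 nM to 120000 nM. Among the compounds with values here, the estimated step that the limit leaves unreadable from compound 3 to compound 4 is expected to be none beyond the scatter, although no measured step can confirm it.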

Compound 4, half-maximal effective concentration: > 22300 nM
Compound 4 was reported as a limit; the forecaster's own chance of this, stated with the estimate: 85%; the middle value is on the limit's open side.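

In this assay compound 4 gives > 22300 nM, which is a limit and not a number. Going by these compounds alone, compound 1, compound 2, compound 3 and compound 4 all give limits, and no step from any of the first three to compound 4 can be read. The compounds shown leave open at what concentration any of these four would reach the half-maximal effect.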